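The compounds below may be only part of what the source reports. "The series", "measured", "known", "first", "only" and "open" are said of these compounds alone.

Going by the values given here, in a functional assay on MCF7 cells (Homo sapiens) for inhibition, read by sulforhodamine B assay (a lower number here means a stronger inhibitor, a higher number a weaker inhibitor), none of the three compounds measured so far gives a number. Compound 1 `O=C1C(Nc2ccccc2F)=CC(=O)c2c1nc1n2[C@H]2OC[C@@H](O)[C@H]2OC1` gives > 4000 nM, which is a limit. Compound 2 `Cc1ccc(NC2=CC(=O)c3c(nc4n3[C@H]3OC[C@@H](O)[C@H]3OC4)C2=O)cc1` gives > 4000 nM, again a limit. Compound 3 `O=C1C(N2CCCCC2)=CC(=O)c2c1nc1n2[C@H]2OC[C@@H](O)[C@H]2OC1` gives > 8000 nM, also a limit, so its place in this assay is bounded on one side only.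

Compound 4 `COc1cccc(NC2=CC(=O)c3c(nc4n3[C@H]3OC[C@@H](O)[C@H]3OC4)C2=O)c1` differs from compound 3 at one place: (3-methoxyphenyl)amino in place of piperidin-1-yl on a double-bonded ring carbon. It carries (3-methoxyphenyl)amino in place of piperidin-1-yl on a double-bonded ring carbon. The closest evidence is a step that the two limits leave unreadable from compound 1 to compound 3 and a step that the two limits leave unreadable from compound 2 to compound 3, since both exchange a substituted phenylamino group and piperidin-1-yl, though in the opposite sense. The step that the two limits leave unreadable from compound 1 to compound 2 compares two such phenylamino groups. None of these steps has a readable size, so they supply no firm size or direction for the change in this assay.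

The expected step is an at least 1.3-fold lower number from compound 3 to compound 4 (0.12 log units; that floor lies within the scatter), an estimate without firm support. Compound 4 is expected to remain a weak inhibitor, with an estimated value of 6000 nM and an expected range from 3000 nM to 12000 nM.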

Compound 4, half-maximal inhibitory concentration: 3830 nM
Beside the measured number, compound 4's estimate is 1.6-fold (0.19 log units) above it; low and high end bracket the measured number.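

In this assay, compound 4 is the first compound shown to give a number rather than a limit, so a change on this double-bonded ring carbon can now be given a size. Putting (3-methoxyphenyl)amino in place of piperidin-1-yl gives an at least 2.0-fold lower number from compound 3 to compound 4 (0.31 log units; beyond the scatter). The changes among the phenyl groups on the amine nitrogen, an at least 1.0-fold lower number from compound 2 to compound 4 (0.01 log units; that floor lies within the scatter) and an at least 1.0-fold lower number from compound 1 to compound 4 (0.01 log units; that floor lies within the scatter), give floors only, because the partner of compound 4 in each step stands at a limit: the limit of > 4000 nM in this assay, at which 2 of the 4 values shown sit.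

From the compounds shown here alone, it remains open whether 3-methoxyphenyl differs at all from 4-methylphenyl or 2-fluorophenyl, and the steps among compound 1, compound 2 and compound 3 cannot be read. The compounds shown also leave open how a phenyl ring carrying a carboxylic acid, or a morpholin-4-yl group on this carbon, would compare.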